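The source may hold more compounds than are shown below. What is called first, only, known or untested is meant among the compounds shown, and "the series" means these compounds.

Of the compounds shown here, two that differ only in one ether chain have been measured so far. In a functional assay on T98G cells (Homo sapiens) for inhibition, read by colorimetric assay and MTT assay, with a stated time of 72 h (on this read-out lower numbers stand for stronger inhibition and higher numbers for weaker inhibition), compound 1 (`C=CCCCCOc1ccccc1-c1cnc(OCCCCC=C)n1C`) gives 4000 nM, while compound 2 (`C=CCCCCCOc1ncc(-c2ccccc2OCCCCC=C)n1C`) gives 63000 nM. Compound 2 therefore holds the higher of the two numbers, which makes it the weaker inhibitor of the pair.

The next compound, compound 3 (`C=CCCCCOc1ccccc1-c1cnc(S(=O)(=O)c2ccccc2)n1C`), has phenylsulfonyl in place of (hept-6-en-1-yl)oxy on an aromatic carbon. This replaces a flexible chain with an aromatic group, so it is a much bigger change than a small adjustment of chain length.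

Going by the values given here, only one measured step bears on it, a 16-fold higher number from compound 1 to compound 2 (1.20 log units; beyond the scatter). That step is large and beyond the scatter, and it alters the same chain that compound 3 loses, so this assay clearly responds to changes at this place. Among the compounds with values here, no measured compound carries phenylsulfonyl, however, so the direction rests on weak evidence. Compound 2 sits at the top of the small range seen so far, which makes a moderate move towards stronger inhibition the likelier outcome, with an estimated 3.2-fold lower number from compound 2 to compound 3 (0.50 log units; beyond the scatter). For compound 3 the expected value is 20000 nM, with an estimated range from 3000 nM to 100000 nM.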

Compound 3, half-maximal inhibitory concentration: 71000 nM
Beside the measured number, compound 3's estimate is 3.6-fold (0.55 log units) below it; the range from low to high includes it.
By their numbers in this assay, from the lowest: compound 1; then compounds 2 and 3 (each within the scatter of the next).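

In this assay, putting phenylsulfonyl in place of (hept-6-en-1-yl)oxy, on the aromatic carbon between two ring nitrogen atoms, gives a 1.1-fold higher number from compound 2 to compound 3 (0.05 log units; within the scatter) and so produces no real difference, even though a chain with no ring gives way to a group with a six-membered aromatic ring. Measured against the (hex-5-en-1-yl)oxy chain of compound 1, the same group gives an 18-fold higher number from compound 1 to compound 3 (1.25 log units; beyond the scatter) as a large loss, which leaves compound 1 as the strongest inhibitor of the three and shows that two very different groups at this position can share the same weak level. Nothing available on these compounds explains this result.

From the compounds shown here alone, what remains open is whether the strength of compound 1 belongs to that one chain length or would also appear with a shorter chain, such as (but-3-en-1-yl)oxy. Going by these compounds, it is equally open how much this position needs a large group at all, since a small group such as an amine or a methoxy on the same carbon would test that directly.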